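Swapping an amino for a methyl: expected effect on cytotoxicity

A few compounds are considered here, and "the series" means these few. Any claim that something is new, unique, unknown or untested is made for them only; others in the source may bear on it.

Measured so far:
compound 1 `c1ccc(-c2ccc(Cn3cncc3CNc3cccc(-c4ccccc4)c3)cc2)cc1`, 10000 nM
compound 2 `COC(=O)c1ccc(NCc2cncn2Cc2ccccc2N)cc1-c1ccccc1`, 25000 nM
compound 3 `Cc1ccccc1-c1ccc(Cn2cncc2CNc2ccc(-c3nc4ccccc4s3)c(-c3ccccc3)c2)cc1`, > 1000 nM

All three compounds were tested in a toxicity assay on NIH3T3 cells (Mus musculus) for cytotoxicity, read by resazurin assay; on this read-out lower numbers stand for an effect already at smaller amounts and higher numbers for an effect only at larger amounts of compound. Compound 2 gives 25000 nM, the higher of the two numbers recorded; compound 1, the nearest, gives 10000 nM, a gap that lies beyond the usual scatter of this assay. Compound 3 gives only > 1000 nM, which is a limit of the assay rather than a number; the same holds for (the limit of > 1000 nM in this assay, at which 1 of the 3 values shown sits).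

Compound 4 `COC(=O)c1ccc(NCc2cncn2Cc2ccccc2C)cc1-c1ccccc1` has not yet been measured. It differs from compound 2 in one place: methyl in place of amino on an aromatic carbon. Going by the values given here, no step between measured compounds matches this change, so there is no direct guide to its size. Since compound 2 sits at 25000 nM, compound 4 is expected to land close by, with a step from a 1.3-fold lower number from compound 2 to compound 4 (0.10 log units; within the scatter) that is not expected to go beyond the scatter in either direction. Compound 4 is therefore estimated at 20000 nM, with a range from 8000 nM to 50000 nM.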

Compound 4, half-maximal effective concentration: 10000 nM
For compound 4 the middle estimate is 2.0-fold (0.30 log units) above the measured one, within the range that was stated.
By their numbers in this assay, from the lowest: compounds 1 and 4 (each within the scatter of the next); then compound 2.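

Putting methyl in place of amino on this aromatic carbon, ortho to a large group, gives a 2.5-fold lower number from compound 2 to compound 4 (0.40 log units; beyond the scatter) in this assay. Going by these compounds alone, this is the first comparison in the set that changes only one place, and it shows that swapping 1 heavy atom here moves the number beyond the scatter, though only modestly. Nothing measured for these compounds explains why the number moves:.

The compounds shown leave open whether the step comes from losing the amino group or from gaining the methyl group, and a hydroxyl group or a chlorine atom on the same carbon would help tell these apart. They also leave open whether the same swap would give a similar step on the core of compound 1.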